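The source may hold more compounds than are shown below. What is called first, only, known or untested is meant among the compounds shown, and "the series" means these compounds.

Measured so far:
- compound 1, `CCC1=C(O)c2c(oc(-c3ccccc3)cc2=O)C(CC)(CC)C1=O`, > 236 uM
- compound 2, `CCC1=C(O)c2c(oc(-c3ccccc3OC)cc2=O)C(CC)(CC)C1=O`, 40.8 uM
- compound 3, `CCC1=C(O)c2c(oc(-c3ccc(OC)c(OC)c3)cc2=O)C(CC)(CC)C1=O`, 14.7 uM

All three share one core and differ only in the groups carried on the phenyl ring at its end. In a functional assay on KB cells (Homo sapiens) for antiproliferative activity, read by sulforhodamine B assay, with a stated time of 3 days (on this read-out higher numbers stand for an effect only at larger amounts of compound and lower numbers for an effect already at smaller amounts), compound 1 gives > 236 uM, and this value is a limit of the assay rather than a number. Compound 2 gives 40.8 uM in this assay. The change from compound 1 to compound 2 is methoxy in place of hydrogen on an aromatic carbon; the step that goes with it is an at least 5.7-fold lower number from compound 1 to compound 2 (0.76 log units; beyond the scatter). Compound 3 gives 14.7 uM in this assay, a lower number than compound 2 and beyond the scatter. How the cores of compound 1 and compound 3 differ is not broken down here.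

Compound 4, `CCC1=C(O)c2c(oc(-c3ccc(OC)c(OC)c3OC)cc2=O)C(CC)(CC)C1=O`, has not been measured in this assay. It differs from compound 3 by methoxy in place of hydrogen on an aromatic carbon. Going by the values given here, this is the same kind of change as the one from compound 1 to compound 2, yet not the same: in compound 2 the new group sits ortho to a large group only, while in compound 4 it sits ortho to a large group, ortho to a methoxy group and meta to a methoxy group. Resting on the step from compound 1 to compound 2, a smaller gain is expected here, estimated as a 1.8-fold lower number from compound 3 to compound 4 (0.26 log units; within the scatter), since compound 3 already starts from 14.7 uM. Compound 4 is therefore expected to give about 8 uM in this assay, most likely between 3 uM and 25 uM.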

Compound 4, concentration for half-maximal effect: 9.4 uM
Estimate against measurement, compound 4: 1.2-fold (0.07 log units) below; the range from low to high includes it.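

The methoxy change again gives a lower number, a 1.6-fold lower number from compound 3 to compound 4 (0.19 log units; within the scatter) in this assay, but a step of this size cannot be told apart from the ordinary spread of repeated measurements. Set beside the earlier case, the same change on a different starting compound does not carry over at the same size, so the gain seen once cannot simply be added on to another member of the series: the same change on two cores in this assay, an at least 5.7-fold lower number (0.76 log units; beyond the scatter) from compound 1 to compound 2 and a 1.6-fold lower number (0.19 log units; within the scatter) from compound 3 to compound 4, at least 3.6-fold (0.56 log units) apart, beyond the scatter of two such steps. Compound 1 sits at a limit of the assay rather than at a number, so the first step has no known upper end, and two steps alone show neither why they differ nor how the change would behave on a further core: the limit of > 236 uM in this assay, at which 1 of the 4 values shown sits.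

Every substituent on the phenyl ring shown here is a methoxy group, which leaves open whether these steps are special to methoxy or would also appear with a hydroxyl group, a fluorine atom or an amine. From the compounds shown here alone, it also remains open whether a longer chain, such as ethoxy in place of methoxy, would move the number further in either direction.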